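This account rests on a few compounds, and the source may have more. Where it says the series, first, only, none or still open, it means among the compounds named here.

Measured so far in a functional assay on MGC-803 cells (Homo sapiens) for inhibition, read by MTT assay, with a stated time of 48 h (on this read-out higher numbers stand for weaker inhibition and lower numbers for stronger inhibition), are three compounds.

- compound 1 `C/C=C/C(=O)N(Cc1ccc(OC)c([N+](=O)[O-])c1)c1cc(OC)c(OC)c(OC)c1` gives 590 nM
- compound 2 `COc1ccc(CNc2cc(OC)c(OC)c(OC)c2)cc1Cl` gives 46200 nM
- compound 3 `COc1ccc(CNc2cc(OC)c(OC)c(OC)c2)cc1Br` gives 29400 nM

Compound 3 sits with compound 2 at the high end of these numbers, the two within the scatter of each other, and far from compound 1 on the side of weaker inhibition.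

The next compound is compound 4 `C/C=C/C(=O)N(Cc1ccc(OC)c(Br)c1)c1cc(OC)c(OC)c(OC)c1`, which departs from compound 3 by (prop-1-en-1-yl)carbonyl in place of hydrogen on a nitrogen on an aromatic ring.

Going by the values given here, the one measured step, a 1.6-fold lower number from compound 2 to compound 3 (0.20 log units; within the scatter), is a swap of chloro for bromo and leaves that nitrogen untouched, so no measured step isolates this change. The nearest evidence is a comparison of two values. Compound 1 already carries the same group on nitrogen and gives 590 nM, while compound 3 gives 29400 nM. That gap is not a clean measure, since compound 1 also has a nitro group where compound 3 has bromo.

A large fall in the number, beyond the scatter, is still expected in this assay, namely a 59-fold lower number from compound 3 to compound 4 (1.77 log units; beyond the scatter) as the estimated step. For compound 4 the estimate is 500 nM, with an expected range of 120 nM to 2500 nM and close to compound 1 in level.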

Compound 4, half-maximal inhibitory concentration: 6430 nM
The estimate for compound 4 lay 13-fold (1.11 log units) below the measured number; the whole stated range lies below it.
By their numbers in this assay, from the lowest: compound 1; then compound 4; then compounds 3 and 2 (each within the scatter of the next).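

In this assay, the (prop-1-en-1-yl)carbonyl in place of hydrogen on a nitrogen on an aromatic ring now has a measured step of its own, a 4.6-fold lower number from compound 3 to compound 4 (0.66 log units; beyond the scatter), so this change alone lowers the number but does not bring compound 4 to the level of compound 1. Going by these compounds alone, with that group held on the nitrogen, the first clean reading of the aromatic carbon also appears: bromo in place of nitro gives an 11-fold higher number from compound 1 to compound 4 (1.04 log units; beyond the scatter), showing that in the acylated series the number depends on the group at that carbon, whereas chloro and bromo with the free nitrogen stand within the scatter of each other in a 1.6-fold lower number from compound 2 to compound 3 (0.20 log units; within the scatter). Nothing on hand gives a reason for either new step.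

As far as these compounds go, whether the effect on the nitrogen needs the double bond of the (prop-1-en-1-yl)carbonyl, or would persist with a saturated butanoyl or a shorter acetyl group, remains open. Also open, from the compounds shown here alone, is how chloro, or an amino group in place of nitro, would read on the acylated compounds, and so whether nitro stands apart at that carbon or bromo alone falls short.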